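A few compounds are considered here, and "the series" means these few. Any claim that something is new, unique, unknown or untested is made for them only; others in the source may bear on it.

Of the compounds shown here, three built on one shared core have been measured in a functional assay on B16-F10 cells (Mus musculus) for antiproliferative activity, read by MTT assay, with a stated time of 48 h; on this read-out higher numbers stand for weaker inhibition and lower numbers for stronger inhibition. Compound 1, with the structure `O=C(/C=C/c1ccc([N+](=O)[O-])cc1)Nc1cc(-c2ccccc2)[nH]n1`, gives 720 nM in this assay. Compound 2, `O=C(/C=C\c1ccc(C(F)(F)F)cc1)Nc1cc(-c2ccccc2)[nH]n1`, gives 640 nM in this assay, while compound 3, `COc1ccc(/C=C/C(=O)Nc2cc(-c3ccc(C)cc3)[nH]n2)cc1`, gives 1370 nM. Among these three numbers compound 1 stands second highest; its nearest neighbour is compound 2 and its furthest is compound 3, yet both gaps fall within the scatter of repeated measurements, so the three compounds cannot be told apart on this read-out.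

Compound 4, `O=C(/C=C/c1ccc(Br)cc1)Nc1cc(-c2ccccc2)[nH]n1`, has not yet been measured. It differs from compound 1 in a single place: bromo in place of nitro on an aromatic carbon. No measured pair in the set differs in only this one place, so nothing in the numbers shown tells how the exchange moves the result. What the numbers do show is that compounds 1, 2 and 3, which carry different groups on their outer rings, all sit within the scatter of one another. On that basis the step of a 1.1-fold higher number from compound 1 to compound 4 (0.05 log units; within the scatter) is expected to be small, with no direction that stands out beyond the scatter. The estimated value for compound 4 is 800 nM, within a range from 350 nM to 1800 nM.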

Compound 4, half-maximal inhibitory concentration: 1380 nM
Compound 4: middle estimate off by 1.7-fold (0.24 log units), on the low side; the measured number falls inside the stated range.
By their numbers in this assay, from the lowest: compounds 2, 1, 3 and 4 (each within the scatter of the next, the first and the last beyond it).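

In this assay, replacing nitro with bromo on the aromatic carbon para to a large group gives a 1.9-fold higher number from compound 1 to compound 4 (0.28 log units; within the scatter). Going by these compounds alone, this is the first direct reading of this position, since the earlier compounds differed from one another in more than one place. The exchange removes a group of three heavy atoms with two hydrogen-bond acceptors and puts in a single bromine atom with none, yet the two numbers cannot be told apart from repeat measurements, so this one swap shows no clear dependence on which of these two groups sits here; no other measurement is available to explain the result.

As far as these compounds go, a single exchange cannot show how far this holds, so it remains open whether an amine, a carboxylic acid or a longer chain at the same carbon would also stay within the scatter of compound 1. From the compounds shown here alone, it is also open whether replacing nitro with bromo would give a similar step if the phenyl ring on the other side of the shared core carried a substituent such as a methoxy group.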